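Going from a Pyrazole to its Methylated Partner

A few compounds are considered here, and "the series" means these few. Any claim that something is new, unique, unknown or untested is made for them only; others in the source may bear on it.

Of the compounds shown here, three measured so far share one core. Compound 1 `Cc1ccnc(-c2ccccc2OCC2=NCCN2)c1`, compound 2 `c1ccc(-c2ccncn2)c(OCC2=NCCN2)c1` and compound 3 `c1ccc(-c2cc[nH]n2)c(OCC2=NCCN2)c1` were all tested in a functional assay for activation of Alpha-1D adrenergic receptor (Homo sapiens), read by calcium flux; on this read-out higher numbers stand for an effect only at larger amounts of compound and lower numbers for an effect already at smaller amounts. In this assay compound 1 gives < 100000 nM, which is a limit of the assay and not a number. Compound 2 likewise gives < 100000 nM, again a limit. Compound 3 gives < 100000 nM, also a limit. The only one-place step among these three, a step that the two limits leave unreadable from compound 2 to compound 3, cannot be read because of the limit of < 100000 nM in this assay, at which 3 of the 3 values shown sit. Compound 3 therefore stands only at a limit, as do the other two compounds.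

Compound 4 `Cn1nccc1-c1ccccc1OCC1=NCCN1` has not yet been measured. It differs from compound 3 by 1-methyl-1H-pyrazol-5-yl in place of 1H-pyrazol-3-yl on an aromatic carbon. Within the data shown here, no measured step bears directly on this change, and the step from compound 2 to compound 3 gives no readable size either. Compound 4 is therefore expected to sit at a similar place as compound 3, with an expected step that the limit leaves unreadable from compound 3 to compound 4 that cannot be told apart from none. Compound 4 is estimated at 30000 nM, with a range from 3000 nM to 100000 nM, and a limit rather than a number is the most likely outcome.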

Compound 4, half-maximal effective concentration: < 100000 nM
Compound 4: a limit, no number; the forecaster's own chance of this, stated with the estimate: 70%; the middle value lies beyond the limit too.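

In this assay compound 4 gives < 100000 nM, which is a limit of the assay and not a number. No new step can be read from compound 2 or compound 3 to compound 4, because all the values rest on the same limit: the limit of < 100000 nM in this assay, at which 4 of the 4 values shown sit. The compounds shown leave open whether 1-methyl-1H-pyrazol-5-yl in place of 1H-pyrazol-3-yl changes the read-out at all.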